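The source may report more compounds than this note shows. Statements on the series, on what has been measured and on what is new or still open speak of the compounds shown alone.

Among the three compounds measured so far, compound 2 `Cc1cc(Cl)cc2nc(N3CCN(C)CC3)oc12` gives the highest number in a functional assay on ileum (strain Hartley) for agonist activity at 5-hydroxytryptamine receptor 3A (Cavia porcellus) (on this read-out lower numbers stand for lower potency and higher numbers for higher potency (the scale is a negative logarithm)), with 6.7. Compound 1 `COc1cc(Cl)cc2nc(N3CCN(C)CC3)oc12` gives 6.16 in this assay, and a number 0.54 log units higher from compound 1 to compound 2 (beyond the scatter). Compound 3 `Cc1cc(C)c2oc(N3CCN(C)CC3)nc2c1` gives 6.32, and a number 0.38 log units lower from compound 2 to compound 3 (beyond the scatter). Since both of these steps lie beyond the scatter, compound 2 stands as the most potent of the three.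

Compound 4 `CCc1cc(Cl)cc2nc(N3CCN(C)CC3)oc12` differs from compound 2 by methyl in place of hydrogen on a saturated chain carbon bound to an aromatic carbon. The step from compound 1 to compound 2 concerns the same group on the shared core and was modest in size; the step from compound 2 to compound 3 concerns another position and is less telling here. Going by the values given here, neither measured step describes the growth of a methyl into an ethyl, so no measured step speaks directly to this change. A small step is therefore expected in this assay, with no assured direction and likely within the scatter, and the expected step is a number 0.10 log units lower from compound 2 to compound 4 (within the scatter). For compound 4 the estimate in this assay is 6.6, with a range from 6.1 to 7.1.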

Compound 4, negative logarithm of the half-maximal effective concentration: 6.82
For compound 4 the middle estimate is 0.22 log units below the measured one; low and high end bracket the measured number.
By their numbers in this assay, from the lowest: compounds 1 and 3 (each within the scatter of the next); then compounds 2 and 4 (each within the scatter of the next).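

In this assay the growth of methyl into ethyl gives a number 0.12 log units higher from compound 2 to compound 4 (within the scatter) and so shows that this position takes the added carbon with no change that stands clear of the scatter. Ethyl in place of methoxy gives a number 0.66 log units higher from compound 1 to compound 4 (beyond the scatter) and points the same way as a number 0.54 log units higher from compound 1 to compound 2 (beyond the scatter) so that both methyl and ethyl give higher numbers than methoxy on this core. Nothing at hand explains these results.

From the compounds shown here alone, whether a longer chain such as propyl, a branched isopropyl group or a hydroxyl on the ethyl chain would keep the number remains open. Also open, going by these compounds, is whether ethyl would behave the same way with methyl in place of chloro on the shared core.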